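A few compounds are considered here, and "the series" means these few. Any claim that something is new, unique, unknown or untested is made for them only; others in the source may bear on it.

Of the compounds shown here, two have been measured in a functional assay on the whole organism (stomach) with Rattus norvegicus as the target; a higher number here means that more compound is needed for the effect, a lower number that less compound is needed. Compound 1 `O=C(O)c1ccc(NC(=O)c2ccc(C(=O)O)cc2)cc1` gives 54.3 mg/kg there. Compound 2 `CCCCc1ccc(C(=O)Nc2cc(C(=O)O)cc(C(=O)O)c2)cc1` shows the highest of the two numbers, at 91.9 mg/kg in this assay, though its gap to compound 1 lies within the scatter. Compound 3 `O=C(O)c1cc(NC(=O)c2ccc(-c3nn[nH]n3)cc2)cc(C(=O)O)c1` has not yet been measured; it differs from compound 2 in one place: 2H-tetrazol-5-yl in place of butyl on an aromatic carbon. Among the measured compounds shown here, no measured pair shows what such a change does here, so only a small step is expected for compound 3, a step of a 1.3-fold lower number from compound 2 to compound 3 (0.12 log units; within the scatter) that stays within the scatter. For compound 3 a value of 70 mg/kg is estimated in this assay, between 30 mg/kg and 160 mg/kg.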

Compound 3, dose for 50% inhibition: 8.2 mg/kg
Compound 3: middle estimate off by 8.5-fold (0.93 log units), on the high side; the measured number lies below the stated range.
By their numbers in this assay, from the lowest: compound 3; then compounds 1 and 2 (each within the scatter of the next).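

In this assay the change from butyl to 2H-tetrazol-5-yl on this aromatic carbon brings an 11-fold lower number from compound 2 to compound 3 (1.05 log units; beyond the scatter) and so shows that the group at this position, para to a large group, strongly affects the dose needed. Among the compounds shown here, this is the first step that lies beyond the scatter. Nothing measured here explains the drop. Going by these compounds, whether the tetrazole ring itself matters remains open, since a carboxylic acid or an amine on the same carbon could be compared with it. A longer chain in place of butyl would show how far the number depends on chain length.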